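A few compounds are considered here, and "the series" means these few. Any claim that something is new, unique, unknown or untested is made for them only; others in the source may bear on it.

Of the compounds shown here, two have so far been measured in an ADME assay on HEK293 cells for agonist activity at Toll-like receptor 8 (Homo sapiens), read by a luciferase reporter, with a stated time of 6 h; on this read-out lower numbers stand for an effect already at smaller amounts and higher numbers for an effect only at larger amounts of compound. Compound 1 `CCCCNc1nc(N)nc2cc(CN(C)C)ccc12` gives 0.04 uM, and compound 2 `CCCCNc1nc(N)nc2ccc(OC)cc12` gives 1.8 uM. Of these two numbers, compound 2 stands at the higher one; its gap to compound 1 is wide and beyond the usual scatter of repeat measurements, so compound 2 needs clearly more material than compound 1 to show an effect. The next compound, compound 3 `CCCCNc1nc(N)nc2ccc(C(C)O)cc12`, keeps the shared core of compound 2 and differs in a single place: 1-hydroxyethyl in place of methoxy on an aromatic carbon. For the measured compounds named here, no measured pair shows this particular change, so the data themselves give no guide to its size. The step is expected to be modest, a 1.8-fold lower number from compound 2 to compound 3 (0.26 log units; within the scatter), with no clear direction beyond the scatter. On that basis compound 3 is expected to give about 1 uM, most likely between 0.2 uM and 5 uM.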

Compound 3, minimum effective concentration: 5.8 uM
The estimate for compound 3 lay 5.8-fold (0.76 log units) below the measured number; measured number outside the range, above it.
By their numbers in this assay, from the lowest: compound 1; then compound 2; then compound 3.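

In this assay, the step from methoxy to 1-hydroxyethyl on this aromatic carbon gives a 3.2-fold higher number from compound 2 to compound 3 (0.51 log units; beyond the scatter) and so lies beyond the scatter. This shows that the number responds to a small change at this place, and here the change moves it upward. The swap adds one carbon and one hydrogen-bond donor at once, and nothing available accounts for the direction or size of the step.

On these data alone, it remains open which part of the swap carries the step, and a hydroxymethyl group or a plain ethyl group on the same carbon would help to separate the two. As far as these compounds go, how a carboxylic acid or a primary amine would behave at this place also remains unknown.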